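The compounds below may be only part of what the source reports. "The series", "measured", "known", "first", "only" and "open" are said of these compounds alone.

Working notes on the series. Compound 1 `CCc1ccc(NS(=O)(=O)c2ccc(N3CCNC3=O)cc2)cc1` gives 810 nM in a functional assay on MCF7 cells (Homo sapiens) for antiproliferative activity, read by sulforhodamine B assay, with a stated time of 48 h; a lower number here means a stronger inhibitor, a higher number a weaker inhibitor. Of the two numbers recorded, compound 1 has the lowest, with compound 2 `CCCCOc1ccc(NS(=O)(=O)c2ccc(N3CCNC3=O)cc2)cc1` nearest at 870 nM, a gap that a 1.1-fold higher number from compound 1 to compound 2 (0.03 log units; within the scatter) leaves within the scatter. Compound 3 `CC(C)Cc1ccc(NS(=O)(=O)c2ccc(N3CCNC3=O)cc2)cc1` returns only a limit, > 1000 nM, in this assay. Compound 3 thus sits at the limit of > 1000 nM in this assay, at which 1 of the 3 values shown sits. The steps of an at least 1.2-fold higher number from compound 1 to compound 3 (0.09 log units; that floor lies within the scatter) and an at least 1.1-fold higher number from compound 2 to compound 3 (0.06 log units; that floor lies within the scatter) likewise stay within the scatter, so the three measured compounds cannot be put in order.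

Compound 4 `Cc1ccc(NS(=O)(=O)c2ccc(N3CCNC3=O)cc2)cc1C` has not yet been measured. It differs from compound 1 by 3,4-dimethylphenyl in place of 4-ethylphenyl on a sulfonamide nitrogen. The three measured steps all alter the group on the sulfonamide nitrogen, and each moved the number by an amount within the scatter. The change to compound 4 is of the same kind, so no step beyond the scatter is expected in this assay. The expected step is a 1.1-fold higher number from compound 1 to compound 4 (0.05 log units; within the scatter). Compound 4 is estimated at 900 nM, within 400 nM to 2000 nM.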

Compound 4, half-maximal inhibitory concentration: 230 nM
Beside the measured number, compound 4's estimate is 3.9-fold (0.59 log units) above it, outside the stated range (below it).
By their numbers in this assay, from the lowest: compound 4; then compounds 1 and 2 (each within the scatter of the next). At a limit, above all of these: compound 3.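

In this assay the group on the sulfonamide nitrogen now gives a 3.5-fold lower number from compound 1 to compound 4 (0.55 log units; beyond the scatter) and so a step beyond the scatter, where the earlier changes at this position stayed within it. The change alters only how the carbons are joined: 4-ethylphenyl and 3,4-dimethylphenyl have the same heavy atoms, the same aromatic ring and no hydrogen-bond donors or acceptors, so the number responds here to an arrangement that these counts do not separate. Nothing recorded for these compounds accounts for this step.

Going by these compounds, whether the step needs both methyl groups of 3,4-dimethylphenyl stays open. So does whether the lower number holds with chloro or methoxy groups in their place.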